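Sigma-1 binding: neopentyl for fluorobenzyl on the amine

The source may hold more compounds than are shown below. What is called first, only, known or untested is meant among the compounds shown, and "the series" means these compounds.

Two compounds in this series have numbers in an assay on membranes from Cortex for displacement of a labelled ligand from Sigma non-opioid intracellular receptor 1 (Cavia porcellus), read by scintillation counting, with a stated time of 120 min; on this read-out higher numbers stand for weaker inhibition and lower numbers for stronger inhibition. Compound 1 `[O-][S+](CCNC1CCN(Cc2ccc(F)cc2)CC1)C(c1ccc(F)cc1)c1ccc(F)cc1` gives 26.5 nM and stands lowest of the two. Compound 2 `O=C(c1cc2ccccc2o1)N1CCC(NCCSC(c2ccc(F)cc2)c2ccc(F)cc2)CC1` gives 304 nM in this assay; the gap between the two values lies beyond the scatter, and the two structures differ in more than one place, so nothing is drawn from the pair.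

Compound 3 `CC(C)(C)CN1CCC(NCC[S+]([O-])C(c2ccc(F)cc2)c2ccc(F)cc2)CC1` differs from compound 1 in one place: tert-butyl in place of 4-fluorophenyl on a saturated chain carbon bound to an amine nitrogen in a ring. For the measured compounds named here, no measured pair in the set shows this kind of exchange, so no step size is known from the data. The expectation is for a modest weakening, roughly at or slightly past the edge of the scatter, as the step from compound 1 to compound 3 a 2.1-fold higher number from compound 1 to compound 3 (0.32 log units; beyond the scatter). Compound 3 is estimated at 55 nM in this assay, with a range of 15 nM to 200 nM.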

Compound 3, inhibition constant: 542 nM
Compound 3: middle estimate off by 9.9-fold (0.99 log units), on the low side; measured number above the stated range.
By their numbers in this assay, from the lowest: compound 1; then compounds 2 and 3 (each within the scatter of the next).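

Moving from 4-fluorobenzyl to neopentyl in this assay gives a 20-fold higher number from compound 1 to compound 3 (1.31 log units; beyond the scatter) and is a large step, so this place on the amine nitrogen in a ring does not tolerate every carbon-only group. For the compounds shown here, the earlier pair differed in more than one place and could show nothing of the kind; this is the first reading of a single change. The step comes with the loss of the six-membered aromatic ring, with hydrogen-bond donor and acceptor counts and net charge unchanged, but the data offer no measured explanation for its size.

On these data alone, it remains open whether the ring itself or its fluorine carries the difference, which plain benzyl would separate from 4-fluorobenzyl. Cyclohexylmethyl or pyridylmethyl at the same place would show how far other rings can stand in.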